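Adding a 3-acetylphenyl Group to the Benzyl Arm

The compounds below may be only part of what the source reports. "The series", "measured", "known", "first", "only" and "open" are said of these compounds alone.

The measured compounds and their values in an assay on isolated protein with Bile acid receptor (Homo sapiens) as the target; a lower number here means that less compound is needed, a higher number that more compound is needed for the effect:

compound 1, `COC(=O)/C=C/c1cccc(N(Cc2ccc(/C=C/c3ccccc3F)cc2)C(=O)C2CCCCC2)c1`: 64 nM
compound 2, `CCOc1cccc(-c2ccc(CN(C(=O)C3CCCCC3)c3cccc(/C=C/C(=O)OC)c3)cc2)c1`: 147 nM
compound 3, `COC(=O)/C=C/c1cccc(N(Cc2ccccc2)C(=O)C2CCCCC2)c1`: > 1000 nM

Compound 3 carries a plain benzyl group and sits at the limit of > 1000 nM in this assay, at which 1 of the 3 values shown sits; its value is a limit of this assay, not a number. Among the three, compound 3 therefore stands at the weak end of what has been measured. Compound 4, `COC(=O)/C=C/c1cccc(N(Cc2ccc(-c3cccc(C(C)=O)c3)cc2)C(=O)C2CCCCC2)c1`, has not yet been measured. It differs from compound 3 by 3-acetylphenyl in place of hydrogen on an aromatic carbon.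

Among the measured compounds shown here, two measured steps bear on this change. Removing the 3-ethoxyphenyl gave an at least 6.8-fold higher number from compound 2 to compound 3 (0.83 log units; beyond the scatter), and removing the 2-(2-fluorophenyl)ethenyl gave an at least 15-fold higher number from compound 1 to compound 3 (1.19 log units; beyond the scatter). Both show that a group at this position of the benzyl ring lowers the number strongly. Since the 3-acetylphenyl of compound 4 resembles the 3-ethoxyphenyl of compound 2 in being an aryl at the same place, a large drop is expected: an at least 6.6-fold lower number from compound 3 to compound 4 (0.82 log units; beyond the scatter). Compound 4 is therefore estimated at 150 nM, with a range from 50 nM to 500 nM.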

Compound 4, half-maximal effective concentration: 227 nM
Compound 4: the middle estimate sits 1.5-fold (0.18 log units) below what was measured, and the stated range covers the measured number.
By their numbers in this assay, from the lowest: compound 1; then compounds 2 and 4 (each within the scatter of the next). At a limit, above all of these: compound 3.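

Going by these compounds, compound 4 shows that the gain at this position is not tied to the ethoxy group: 3-acetylphenyl, para to a large group, also gives in this assay an at least 4.4-fold lower number from compound 3 to compound 4 (0.64 log units; beyond the scatter), although the value of compound 3 is a limit of the assay and not a number, so the full size of this step is unknown. Exchanging the outer group's ethoxy for acetyl gives a 1.5-fold higher number from compound 2 to compound 4 (0.19 log units; within the scatter), so this assay does not separate these two groups. The 2-(2-fluorophenyl)ethenyl group still keeps a modest edge over 3-acetylphenyl, as the reverse exchange gives a 3.5-fold higher number from compound 1 to compound 4 (0.55 log units; beyond the scatter).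

On these data alone, whether a plain phenyl group would do as well as these two substituted rings stays open. So does the outcome with an amine, a carboxylic acid or a longer chain in place of the acetyl.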